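Swapping a hydroxy for a bromo on a hydrazone scaffold

This account rests on a few compounds, and the source may have more. Where it says the series, first, only, none or still open, it means among the compounds named here.

Measured so far:
- compound 1 `O=C(COc1cccc2ccccc12)N/N=C/c1cccc(O)c1`: 62.7 ug/mL
- compound 2 `COc1ccc(/C=N/NC(=O)COc2cccc3ccccc23)cc1O`: 27.7 ug/mL

In an ADME assay on HEL cells (Homo sapiens) for cytotoxicity (a lower number here means that less compound is tolerated, a higher number that more compound is tolerated), compound 1 stands at the highest of the two numbers, with compound 2 the nearest neighbour. Going by the values given here, the one measured step, a 2.3-fold lower number from compound 1 to compound 2 (0.35 log units; beyond the scatter), comes from adding a group to the ring that carries the hydroxy.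

Compound 3 `O=C(COc1cccc2ccccc12)N/N=C/c1cccc(Br)c1` differs from compound 1 by bromo in place of hydroxy on an aromatic carbon. Among the compounds with values here, no measured step matches this exchange: the only step available adds a group rather than replacing one, so it offers a weak guide at best. It shows that a small change on that ring can move this assay by a modest amount, and a similar modest shift, or none beyond the scatter, is the expectation here. The estimated step is a 1.4-fold lower number from compound 1 to compound 3 (0.14 log units; within the scatter), a slight move toward lower tolerance. Compound 3 is therefore estimated at 45 ug/mL, with a range from 20 ug/mL to 100 ug/mL.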

Compound 3, half-maximal cytotoxic concentration: 48.6 ug/mL
The estimate for compound 3 lay 1.1-fold (0.03 log units) below the measured number; the range from low to high includes it.
By their numbers in this assay, from the lowest: compounds 2, 3 and 1 (each within the scatter of the next, the first and the last beyond it).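

In this assay the exchange of 3-hydroxyphenyl to 3-bromophenyl gives a 1.3-fold lower number from compound 1 to compound 3 (0.11 log units; within the scatter) and so leaves the number within the scatter of compound 1. Going by these compounds alone, this is the first look at a replacement at this place on the ring: the hydroxy, counted as a hydrogen-bond donor and acceptor, gives way to a bromo counted as neither, with no step beyond the scatter. Nothing measured here offers an explanation for this result.

The compounds shown leave open how this assay responds to quite different groups at this place, such as an amine, a carboxylic acid or a longer chain like propoxy. They also leave open whether bromo would give a similar number at another place on the ring or on a changed core.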